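Phenyl return on the acid side of the series

The compounds below may be only part of what the source reports. "The series", "measured", "known", "first", "only" and "open" are said of these compounds alone.

- Compound 1 `C=C[C@@](C)(/C=C/c1ccc(O)c(/C=C/C(=O)c2ccccc2)c1)CCC=C(C)C`: 4470 nM
- Compound 2 `C=C[C@@](C)(/C=C/c1ccc(O)c(/C=C/C(=O)O)c1)CCC=C(C)C`: > 43400 nM
- Compound 3 `C=C[C@@](C)(/C=C/c1ccc(O)c(/C=C/C=C/c2ccccc2)c1)CCC=C(C)C`: not yet measured

Compound 2 is the reference point here. In a functional assay on NALM-6 cells (Homo sapiens) for cytotoxicity, with a stated time of 72 h (on this read-out lower numbers stand for an effect already at smaller amounts and higher numbers for an effect only at larger amounts of compound), compound 2 stands at > 43400 nM, and this is a limit of the assay, not a number. The series offers one measured step, an at least 9.7-fold higher number from compound 1 to compound 2 (0.98 log units; beyond the scatter), with hydroxy in place of phenyl on a carbonyl carbon.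

The change now in question is 2-phenylethenyl in place of carboxy on a double-bonded chain carbon bound to a double-bonded chain carbon. Compound 3 loses the carboxy and carries a phenyl ring again, so the step of an at least 9.7-fold higher number from compound 1 to compound 2 (0.98 log units; beyond the scatter) bears on it when read backwards. Going by the values given here, that step is the only guide, and it does not cover this exact change, so the range is kept wide. A move to a lower number of comparable size, beyond the scatter, is expected, and the estimate is an at least 8.6-fold lower number from compound 2 to compound 3 (0.93 log units; beyond the scatter). For compound 3 the expected value is 5000 nM, with an estimated range of 1500 nM to 20000 nM.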

Compound 3, half-maximal effective concentration: > 43400 nM
Compound 3: a limit, no number; the forecaster's own chance of this, stated with the estimate: 10%; at least 8.6-fold (0.93 log units) between middle value and limit.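

In this assay the change from benzoyl to 2-phenylethenyl gives an at least 9.7-fold higher number from compound 1 to compound 3 (0.98 log units; beyond the scatter) so a phenyl ring at this place does not by itself bring back a measurable effect. Of the three compounds, only compound 1, the one with benzoyl, gives a number rather than a limit, which makes the earlier step too narrow a guide: the phenyl ring and the carbonyl count together here, at least across these three compounds. The comparison of compound 2 with compound 3 cannot be read because both values are limits, not numbers: the limit of > 43400 nM in this assay, at which 2 of the 3 values shown sit.

Whether the carbonyl alone carries the effect stays open, since no compound shown has a carbonyl without the phenyl ring other than the carboxylic acid of compound 2; a methyl ketone or an amide at this place would separate the two. Also open, as far as these compounds go, is whether compound 2 and compound 3 differ at all, as the limit hides any difference between them.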